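This account rests on a few compounds, and the source may have more. Where it says the series, first, only, none or still open, it means among the compounds named here.

Measured compounds:
- compound 1, `COc1ccc(OC)c(/C=N/NC(=O)Nc2ccc(Oc3ccnc(-c4nncn4CCN(C)C)c3)c(F)c2)c1`: 2070 nM in a functional assay on HT-29 cells (Homo sapiens) for cytotoxicity, read by MTT assay, with a stated time of 72 h; on this read-out lower numbers stand for stronger inhibition and higher numbers for weaker inhibition
- compound 2, `CN(C)CCn1cnnc1-c1cc(Oc2ccc(NC(=O)N/N=C/c3ccc(F)cc3)cc2F)ccn1`: 1370 nM

For the measured compounds named here, compound 2 holds the lowest of the two numbers in this assay, but the one step to it, a 1.5-fold lower number from compound 1 to compound 2 (0.18 log units; within the scatter), lies within the scatter, so compound 1 and compound 2 are not distinguished on these data.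

Compound 3, `CN(C)CCn1cnnc1-c1cc(Oc2ccc(NC(=O)N/N=C/c3ccc(O)cc3)cc2F)ccn1`, is not yet measured. Against compound 2 the difference is hydroxy in place of fluoro on an aromatic carbon.

Going by the values given here, no measured step touches the hydroxy group; the only step, a 1.5-fold lower number from compound 1 to compound 2 (0.18 log units; within the scatter), swaps one aryl for another and was within the scatter. Among the compounds with values here, the exchange of fluoro for hydroxy on the same aromatic carbon therefore has no direct precedent here, and with one step that itself showed no movement, no step beyond the scatter is expected, in either direction.

Compound 3 is estimated at 1500 nM in this assay, range 500 nM to 4500 nM, which is expected to mean a 1.1-fold higher number from compound 2 to compound 3 (0.04 log units; within the scatter).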

Compound 3, half-maximal inhibitory concentration: 1920 nM
Compound 3: the middle estimate sits 1.3-fold (0.11 log units) below what was measured, and the stated range covers the measured number.
By their numbers in this assay, from the lowest: compounds 2, 3 and 1 (each within the scatter of the next).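

In this assay the change from 4-fluorophenyl to 4-hydroxyphenyl gives a 1.4-fold higher number from compound 2 to compound 3 (0.15 log units; within the scatter) and so shows that this aromatic carbon accepts a hydroxy group, with its hydrogen-bond donor and acceptor, without a shift that can be told from the scatter. The comparison with the 2,5-dimethoxyphenyl group gives a 1.1-fold lower number from compound 1 to compound 3 (0.03 log units; within the scatter) and is equally unresolved, so the 2,5-dimethoxyphenyl, 4-fluorophenyl and 4-hydroxyphenyl groups remain undistinguished on this read-out. No supporting evidence is available to explain this flat response.

As far as these compounds go, whether an amine or a carboxylic acid on the same aromatic carbon would also stay within the scatter remains open. Also open, from the compounds shown here alone, is whether any change at this position can move the number beyond the scatter in this assay at all.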